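This account rests on a few compounds, and the source may have more. Where it says the series, first, only, none or still open, it means among the compounds named here.

Two members of the series have been run in a functional assay for inhibition, with Homo sapiens as the target; a lower number here means a stronger inhibitor, a higher number a weaker inhibitor. Compound 1 `Fc1cccc(Nc2nccc(-c3ccccn3)n2)c1` gives 1000 nM there. Compound 2 `c1cc(Nc2nccc(-c3ccco3)n2)cc(-n2ccnc2)c1` gives 800 nM, the lowest of the two numbers; the number for compound 1 lies within the scatter of it. Compound 3 `CCc1cccc(Nc2nccc(-c3ccco3)n2)c1` awaits measurement. It differs from compound 2 by ethyl in place of 1H-imidazol-1-yl on an aromatic carbon. For the measured compounds named here, no measured pair shows this change, so the series gives no direction for it; no step beyond the scatter is expected. Compound 3 is expected to give about 1000 nM in this assay, within 400 nM to 2500 nM, an expected step of a 1.3-fold higher number from compound 2 to compound 3 (0.10 log units; within the scatter).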

Compound 3, half-maximal inhibitory concentration: 9700 nM
Beside the measured number, compound 3's estimate is 9.7-fold (0.99 log units) below it; the whole stated range lies below it.
By their numbers in this assay, from the lowest: compounds 2 and 1 (each within the scatter of the next); then compound 3.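

On the aromatic carbon meta to a large group, the substituent matters in this assay: ethyl in place of 1H-imidazol-1-yl gives a 12-fold higher number from compound 2 to compound 3 (1.08 log units; beyond the scatter). For the compounds shown here, this is the first single-place comparison, since compound 1 differs from compound 2 in more than one place. No data here bear on the reason for this step.

This one pair cannot separate the loss of the five-membered aromatic ring from the loss of its nitrogens as hydrogen-bond acceptors. An amine, a pyridine ring or a longer chain at this carbon would test which of these matters.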